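The source may hold more compounds than are shown below. What is called first, only, known or untested is meant among the compounds shown, and "the series" means these compounds.

Measured compounds:
- compound 2, `CN1CCN(c2ccc(Nc3nc(-c4cccc(NC(=O)c5ccccc5)c4)sc3C(N)=O)cc2)CC1`, 6360 nM in a functional assay on Raji cells (Homo sapiens) for antiproliferative activity, read by CCK-8 assay, with a stated time of 72 h; a higher number here means a weaker inhibitor, a lower number a stronger inhibitor
- compound 1, `CN1CCN(c2ccc(Nc3nc(-c4cccc(NC(=O)c5ccc(C(C)(C)C)cc5)c4)sc3C(N)=O)cc2)CC1`, "not determined" (no result reported) in this assay

Within the data shown here, compound 2 is the only compound of the series with a number in this assay; compound 1 carries no result, so no step between measured compounds can be drawn and no size of effect for any change has been seen.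

Compound 3, `CN1CCN(c2ccc(Nc3nc(-c4cccc(NC(=O)c5ccc(F)c(Cl)c5)c4)sc3C(N)=O)cc2)CC1`, is not yet measured. It differs from compound 2 by 3-chloro-4-fluorophenyl in place of phenyl on a carbonyl carbon, the carbonyl carbon whose other neighbour is the amide-type nitrogen.

Among the measured compounds shown here, with no measured step to lean on, the expectation is a small step, toward a somewhat lower number but not clearly beyond the usual scatter; the estimated step is a 1.6-fold lower number from compound 2 to compound 3 (0.20 log units; within the scatter). Compound 3 is therefore expected to give about 4000 nM in this assay, within a range of 1300 nM to 12000 nM.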

Compound 3, half-maximal inhibitory concentration: 6230 nM
Estimate against measurement, compound 3: 1.6-fold (0.19 log units) below; low and high end bracket the measured number.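

In this assay this position gives its first readable step, a 1.0-fold lower number from compound 2 to compound 3 (0.01 log units; within the scatter), for 3-chloro-4-fluorophenyl in place of phenyl on a carbonyl carbon. The two compounds cannot be told apart here, so placing chlorine and fluorine together on this aromatic ring produces no effect that can be separated from the scatter. Nothing at hand bears on why the two compounds read alike.

Steps to compound 1 cannot be read, so the series still has no step at this position that lies beyond the scatter. Open questions are whether a single chlorine or a single fluorine on the ring would read like the pair, and whether an amine or a carboxylic acid on the ring, or a cyclohexyl group in place of the phenyl, would shift the number.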